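This account rests on a few compounds, and the source may have more. Where it says the series, first, only, none or still open, it means among the compounds named here.

Of the compounds shown here, three have so far been measured in a functional assay on CHO cells for agonist activity at prostaglandin F2-alpha receptor (Homo sapiens), read by fluorescence and calcium flux; on this read-out lower numbers stand for an effect already at smaller amounts and higher numbers for an effect only at larger amounts of compound. Compound 1 `O=C(O)CCC/C=C\C[C@@H]1[C@@H](/C=C/[C@@H](O)CCc2ccccc2)[C@H](O)C[C@@H]1O` gives 12 nM. Compound 2 `CS(=O)(=O)NC(=O)CCC/C=C\C[C@@H]1[C@@H](/C=C/[C@@H](O)COc2ccccc2)[C@H](O)C[C@@H]1O` gives 1800 nM. Compound 3 `O=C(O)CCC1=CC[C@@H]2[C@@H](/C=C/[C@@H](O)COc3ccccc3)[C@H](O)C[C@@H]2OC1` gives 530 nM, the second-highest number of the three; it stands closer to compound 2 than to compound 1, and both gaps lie beyond the scatter. From compound 3 the study moves to compound 4 `O=C(O)CCCCCC1=CC[C@@H]2[C@@H](/C=C/[C@@H](O)COc3ccccc3)[C@H](O)C[C@@H]2OC1`. The change is 3-carboxypropyl in place of carboxy on a saturated chain carbon, two bonds along the chain from a double-bonded ring carbon. Among the measured compounds shown here, no measured pair shows this change on its own, so the step can only be guessed. Because compound 1 reaches 12 nM and compound 4 comes nearer to it in the length of the acid chain, a shift toward lower numbers is expected, with the step of a 3.5-fold lower number from compound 3 to compound 4 (0.55 log units; beyond the scatter) taken as moderate. Compound 4 is estimated at 150 nM, within 30 nM to 1500 nM.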

Compound 4, half-maximal effective concentration: 880 nM
Beside the measured number, compound 4's estimate is 5.9-fold (0.77 log units) below it, and the stated range covers the measured number.
By their numbers in this assay, from the lowest: compound 1; then compounds 3 and 4 (each within the scatter of the next); then compound 2.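

Putting 3-carboxypropyl in place of carboxy on a saturated chain carbon, two bonds along the chain from a double-bonded ring carbon, gives a 1.7-fold higher number from compound 3 to compound 4 (0.22 log units; within the scatter) in this assay. Among the compounds shown here, this is the first step that can be read at this position, and on this core the read-out does not tell these two chain ends apart. Nothing given here offers an explanation for this result.

The compounds shown leave open how a methyl ester or a primary amide in place of the acid on this chain would read, and whether a chain of intermediate length would differ from either end.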